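Moving the Chloro Group on the Carboxyphenyl Ring

The compounds below may be only part of what the source reports. "The series", "measured", "known", "first", "only" and "open" are said of these compounds alone.

Measured so far:
- compound 1 `Cc1c(OCCCCOc2ccc(C(=O)O)c(Cl)c2)ccc(C(=O)CC(C)C)c1O`: 2050 nM
- compound 2 `Cc1cc(OCCCCOc2ccc(C(=O)CC3CCCC3)c(O)c2C)ccc1C(=O)O`: > 10000 nM
- compound 3 `Cc1c(OCCCCOc2ccc(C(=O)O)c(Cl)c2)ccc(C(=O)CC2CCCC2)c1O`: 2250 nM

In an assay on HEK293 cells for positive allosteric modulation of metabotropic glutamate receptor 3 (Rattus norvegicus), read by thallium flux, with a stated time of 2.5 min (on this read-out lower numbers stand for an effect already at smaller amounts and higher numbers for an effect only at larger amounts of compound), compound 1 gives 2050 nM, the lowest of the two numbers shown. Its nearest neighbour is compound 3, and a 1.1-fold higher number from compound 1 to compound 3 (0.04 log units; within the scatter), so the two cannot be ranked. For compound 2 the assay reports only a limit, > 10000 nM, not a number; the limit of > 10000 nM in this assay, at which 1 of the 3 values shown sits, marks where it sits.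

Compound 4 `Cc1c(OCCCCOc2ccc(C(=O)O)cc2Cl)ccc(C(=O)CC(C)C)c1O` has not yet been measured. It differs from compound 1 in one place: 4-carboxy-2-chlorophenyl in place of 4-carboxy-3-chlorophenyl on an oxygen on a saturated carbon. The same atoms are present in both; only the chloro position on the carboxyphenyl ring changes.

Among the compounds with values here, no measured step moves a chloro group from one ring position to another. The closest evidence is an at least 4.4-fold lower number from compound 2 to compound 3 (0.64 log units; beyond the scatter), which shows that the substituent on that ring does matter, while a 1.1-fold higher number from compound 1 to compound 3 (0.04 log units; within the scatter) shows the other end of the molecule tolerates change. Because of an at least 4.4-fold lower number from compound 2 to compound 3 (0.64 log units; beyond the scatter) a step of modest size in either direction is plausible, but the data give no direction, so compound 4 is expected near compound 1, with a 1.5-fold higher number from compound 1 to compound 4 (0.17 log units; within the scatter). The estimate for compound 4 is 3000 nM, ranging from 1000 nM to 10000 nM.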

Compound 4, half-maximal effective concentration: 1140 nM
Estimate against measurement, compound 4: 2.6-fold (0.42 log units) above; low and high end bracket the measured number.
By their numbers in this assay, from the lowest: compounds 4, 1 and 3 (each within the scatter of the next). At a limit, above all of these: compound 2.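

Within the data shown here, compound 4 gives the first direct reading on where the chloro group sits on the carboxyphenyl ring, and in this assay there is a 1.8-fold lower number from compound 1 to compound 4 (0.25 log units; within the scatter). With the rest of the molecule unchanged, 4-carboxy-2-chlorophenyl and 4-carboxy-3-chlorophenyl therefore cannot be ranked, and this ring accepts either arrangement of the chloro group without a step beyond the scatter. No measurement shown explains this result.

The compounds shown leave open whether the two chloro arrangements would also match when the cyclopentyl group replaces the isopropyl group at the other end of the molecule. They also leave open what a 4-carboxy-2-fluorophenyl group, a 4-carboxy-2-methylphenyl group or a plain 4-carboxyphenyl group with no halogen would do in the same place.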